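The compounds below may be only part of what the source reports. "The series", "measured", "known", "first", "only" and "open" are said of these compounds alone.

The measured compounds in a functional assay on cells for positive allosteric modulation of metabotropic glutamate receptor 5 (Rattus norvegicus), read by calcium flux; a lower number here means that less compound is needed, a higher number that more compound is needed for the effect:
compound 1 `O=C(Nc1cc(-c2ccccc2)nn1-c1ccccc1)c1ccccc1` gives 203 nM;
compound 2 `O=C(Nc1cc(-c2ccccc2)nn1-c1ccccc1)c1cccc([N+](=O)[O-])c1` gives 39 nM;
compound 3 `O=C(Nc1cc(-c2ccccc2)nn1-c1ccccc1)c1ccc([N+](=O)[O-])cc1` gives 10.7 nM.

Compound 3 stands lowest of the three numbers: a 3.6-fold lower number from compound 2 to compound 3 (0.56 log units; beyond the scatter) and a 19-fold lower number from compound 1 to compound 3 (1.28 log units; beyond the scatter), both beyond the scatter. Compound 4 `COc1cc(OC)cc(C(=O)Nc2cc(-c3ccccc3)nn2-c2ccccc2)c1` differs from compound 3 by 3,5-dimethoxyphenyl in place of 4-nitrophenyl on a carbonyl carbon. For the measured compounds named here, two measured steps bear on this change. The step of a 3.6-fold lower number from compound 2 to compound 3 (0.56 log units; beyond the scatter) shows that a shift of the nitro within that ring alone moves the number by a modest amount, and a 19-fold lower number from compound 1 to compound 3 (1.28 log units; beyond the scatter) shows how far compound 3 stands from compound 1 once the nitro is in place. Compound 4 gives up that nitro and takes two methoxy groups, for which no measured comparison exists among these compounds, so its number is expected to move back toward that of compound 1 rather than stay with compound 3, with the size of the methoxy contribution unknown. Compound 4 is therefore expected to give 120 nM, within 25 nM to 600 nM, which means a step of an 11-fold higher number from compound 3 to compound 4 (1.05 log units; beyond the scatter) in this assay.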

Compound 4, half-maximal effective concentration: 2040 nM
Beside the measured number, compound 4's estimate is 17-fold (1.23 log units) below it; the measured number lies above the stated range.
By their numbers in this assay, from the lowest: compound 3; then compound 2; then compound 1; then compound 4.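

In this assay, for the compounds shown here, the earlier compounds showed only the number falling when a nitro took the place of hydrogen on this ring, whereas the 3,5-dimethoxyphenyl group shows that a substituted ring on this carbonyl carbon can also raise it, with a 10-fold higher number from compound 1 to compound 4 (1.00 log units; beyond the scatter) against the plain phenyl. Against the nitro compounds the change is larger, with a 52-fold higher number from compound 2 to compound 4 (1.72 log units; beyond the scatter) and a 190-fold higher number from compound 3 to compound 4 (2.28 log units; beyond the scatter), so the two kinds of substituted ring lie on opposite sides of compound 1. Nothing measured here accounts for this difference.

The compounds shown leave open whether one methoxy group alone already raises the number or whether the change takes both. They also leave open where an amine, a nitrile or a carboxylic acid in place of the nitro would stand.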